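The source may hold more compounds than are shown below. What is called first, only, known or untested is meant among the compounds shown, and "the series" means these compounds.

Compound 2 `O=c1ccoc2cc(OCc3cn(Cc4ccc(Br)cc4)nn3)ccc12` was tested in an ADME assay on L02 cells (Homo sapiens) for cytotoxicity, read by MTT assay, with a stated time of 48 h; on this read-out lower numbers stand for stronger inhibition and higher numbers for weaker inhibition. In this assay compound 2 gives > 300000 nM, which is a limit of the assay rather than a number. Compound 1 `O=c1ccoc2cc(OCc3cn(Cc4cccc([N+](=O)[O-])c4)nn3)ccc12`, which differs from it only in the group on the saturated chain carbon bound to an aromatic nitrogen, gives in this assay > 300000 nM, again a limit. The step that the two limits leave unreadable from compound 1 to compound 2 therefore cannot be read in size or direction. Among the measured compounds shown here, both values sit at the limit of > 300000 nM in this assay, at which 2 of the 2 values shown sit, and no measured step gives a scale for what an exchange at this position does. Compound 3 `O=c1ccoc2cc(OCc3cn(Cc4ccccc4F)nn3)ccc12` carries 2-fluorophenyl in place of 4-bromophenyl on a saturated chain carbon bound to an aromatic nitrogen. For the measured compounds named here, no measured step bears on this change, and with two limits in hand the expectation is for no move beyond the scatter, estimated as a number no higher from compound 2 to compound 3 (the limit leaves the size open). Compound 3 is thus expected to give about 300000 nM in this assay, within a range from 100000 nM to 1000000 nM, most likely again only as a limit.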

Compound 3, half-maximal inhibitory concentration: > 300000 nM
Compound 3 ended at the assay's limit; the forecaster's own chance of this, stated with the estimate: 80%; the middle value sits exactly at the limit.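

Compound 3, like compound 1 and compound 2, gives only a limit, so the steps among these three compounds cannot be read in size or direction: the limit of > 300000 nM in this assay, at which 3 of the 3 values shown sit.

The compounds shown leave open whether in this assay any exchange at this position changes the read-out at all.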